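The source may report more compounds than this note shows. Statements on the series, on what has been measured and on what is new or still open speak of the compounds shown alone.

In a functional assay on DU-145 cells (Homo sapiens) for inhibition, read by sulforhodamine B assay, with a stated time of 48 h (on this read-out lower numbers stand for stronger inhibition of growth and higher numbers for weaker inhibition of growth), compound 1 (`O=C(Cc1csc2nc(-c3ccc(Br)cc3)cn12)N/N=C/c1ccccc1`) gives 14500 nM on the shared core, while compound 2 (`O=C(Cc1csc2nc(-c3ccc(Br)cc3)cn12)N/N=C/c1ccccc1O`) gives 2880 nM and compound 3 (`O=C(Cc1csc2nc(-c3ccc(Br)cc3)cn12)N/N=C/c1ccc(O)cc1`) gives 22400 nM as the highest number of the three. Compound 3 thus stands level with compound 1 within the scatter and clearly above compound 2. Still to be measured is compound 4 (`COc1cccc(OC)c1/C=N/NC(=O)Cc1csc2nc(-c3ccc(Br)cc3)cn12`), which has 2,6-dimethoxyphenyl in place of 4-hydroxyphenyl on a carbon with a double bond to nitrogen. Hydroxy in place of hydrogen gave a 5.0-fold lower number from compound 1 to compound 2 (0.70 log units; beyond the scatter) in one case but only a 1.5-fold higher number from compound 1 to compound 3 (0.19 log units; within the scatter) in the other, and 4-hydroxyphenyl in place of 2-hydroxyphenyl gave a 7.8-fold higher number from compound 2 to compound 3 (0.89 log units; beyond the scatter) as the largest step seen. None of these steps involves a methoxy group, so they bear on the change only indirectly. By name, the entering group resembles the 2-hydroxyphenyl of compound 2 (2880 nM) more than the group it replaces, which points toward a lower number, though with little certainty. The expected step is a 2.5-fold lower number from compound 3 to compound 4 (0.40 log units; beyond the scatter) in this assay and would be modest in size. For compound 4 the estimated value is 9000 nM with a range from 2500 nM to 30000 nM expected.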

Compound 4, concentration for 50% growth inhibition: 17800 nM
For compound 4 the middle estimate is 2.0-fold (0.30 log units) below the measured one, within the range that was stated.
By their numbers in this assay, from the lowest: compound 2; then compounds 1, 4 and 3 (each within the scatter of the next).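

In this assay, 2,6-dimethoxyphenyl in place of 4-hydroxyphenyl gives a 1.3-fold lower number from compound 3 to compound 4 (0.10 log units; within the scatter), and in place of phenyl it gives a 1.2-fold higher number from compound 1 to compound 4 (0.09 log units; within the scatter), so on the carbon with a double bond to nitrogen these three aromatic groups cannot be told apart in this assay. In place of 2-hydroxyphenyl, the same group gives a 6.2-fold higher number from compound 2 to compound 4 (0.79 log units; beyond the scatter), which shows that a ring carrying two methoxy groups does not share the lower number of compound 2 and leaves compound 2 as the only one of the four set apart from the rest. Nothing given here explains why 2-hydroxyphenyl stands apart from 2,6-dimethoxyphenyl.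

The compounds shown leave open whether a phenyl carrying a single methoxy group would stand with compound 2 or with compound 4, which would separate the effect of having one oxygen-bearing group from that of having two. They also leave open whether an amine in place of the hydroxy of 2-hydroxyphenyl would keep the lower number seen for compound 2.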